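The source may report more compounds than this note shows. Statements on the series, on what has been measured and on what is new or still open speak of the compounds shown alone.

Of the compounds shown here, three that share one core have been tested in an ADME assay on Vero cells (Chlorocebus sabaeus) for cytotoxicity, read by MTT assay, with a stated time of 72 h; on this read-out higher numbers stand for lower toxicity in this test and lower numbers for higher toxicity in this test. Compound 1, `O=C(c1ccccc1F)N1CCN(c2nc(=O)c3cc(C(F)(F)F)cc([N+](=O)[O-])c3s2)CC1`, reaches only a limit of the assay: in this assay compound 1 gives > 125000 nM. Compound 2, `O=C(c1ccccc1Cl)N1CCN(c2nc(=O)c3cc(C(F)(F)F)cc([N+](=O)[O-])c3s2)CC1`, also reaches only a limit, and in this assay compound 2 gives > 125000 nM. Compound 3, `CCC(C)C(=O)N1CCN(c2nc(=O)c3cc(C(F)(F)F)cc([N+](=O)[O-])c3s2)CC1`, stands at a limit as well, giving in this assay > 125000 nM. The measured steps are therefore a step that the two limits leave unreadable from compound 1 to compound 2, a step that the two limits leave unreadable from compound 1 to compound 3 and a step that the two limits leave unreadable from compound 2 to compound 3, and all that can be said is the limit of > 125000 nM in this assay, at which 3 of the 3 values shown sit.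

Compound 4, `O=C(C1CCCCC1)N1CCN(c2nc(=O)c3cc(C(F)(F)F)cc([N+](=O)[O-])c3s2)CC1`, differs from compound 3 by cyclohexyl in place of sec-butyl on a carbonyl carbon. The two steps that already exchange the group on the carbonyl carbon, a step that the two limits leave unreadable from compound 1 to compound 3 and a step that the two limits leave unreadable from compound 2 to compound 3, left no readable size, so no direction beyond the scatter is expected. The step from compound 3 to compound 4 is estimated as a step that the limit leaves unreadable from compound 3 to compound 4. Compound 4 is thus expected to give about 150000 nM, within a range from 60000 nM to 400000 nM, most likely again reported as a limit.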

Compound 4, half-maximal cytotoxic concentration: 88700 nM
The estimate for compound 4 lay 1.7-fold (0.23 log units) above the measured number; low and high end bracket the measured number.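

Among the compounds shown here, compound 4 is the first compound here to give a real number rather than a limit in this assay, so cyclohexyl provides the first readable value for a group on this carbonyl carbon. The exchange gives an at least 1.4-fold lower number from compound 3 to compound 4 (0.14 log units; that floor lies within the scatter), an at least 1.4-fold lower number from compound 2 to compound 4 (0.14 log units; that floor lies within the scatter) and an at least 1.4-fold lower number from compound 1 to compound 4 (0.14 log units; that floor lies within the scatter); each of these is only a floor, and none shows by itself a difference beyond the scatter. The other compounds give no number to set beside it: the limit of > 125000 nM in this assay, at which 3 of the 4 values shown sit.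

The steps among compound 1, compound 2 and compound 3 cannot be read, so nothing separates sec-butyl, 2-fluorophenyl and 2-chlorophenyl. From the compounds shown here alone, it also remains open how this read-out would respond to an amine, a carboxylic acid or a longer carbon chain on the same carbonyl carbon.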